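The source may hold more compounds than are shown below. What is called first, only, known or untested is meant among the compounds shown, and "the series" means these compounds.

Measured compounds in an assay on cells for inhibition of Amine oxidase [flavin-containing] B (Homo sapiens), read by Amplex Red, with a stated time of 30 min; on this read-out lower numbers stand for stronger inhibition and higher numbers for weaker inhibition:
compound 1 `O=C1COC(c2ccc(/N=N/c3cccc(Cl)c3)cc2)=NN1` — 287 nM
compound 2 `O=C1COC(c2ccc(/C=C/c3ccccc3)cc2)=NN1` — 165 nM

In this assay compound 1 gives 287 nM and compound 2 gives 165 nM. The two numbers fall within the scatter of each other, so compound 2 is not separated from compound 1 on what has been measured. Compound 3 `O=C1COC(c2ccc(/C=C/c3cccc(F)c3)cc2)=NN1` differs from compound 2 by fluoro in place of hydrogen on an aromatic carbon, meta to a large group. Among the compounds with values here, no measured pair shows this change, so no step beyond the scatter is expected in this assay in either direction. Compound 3 is expected to give about 150 nM, between 60 nM and 400 nM, an expected step of a 1.1-fold lower number from compound 2 to compound 3 (0.04 log units; within the scatter).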

Compound 3, half-maximal inhibitory concentration: 22 nM
Beside the measured number, compound 3's estimate is 6.8-fold (0.83 log units) above it; measured number outside the range, below it.
By their numbers in this assay, from the lowest: compound 3; then compounds 2 and 1 (each within the scatter of the next).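

In this assay the change from phenyl to 3-fluorophenyl gives a 7.5-fold lower number from compound 2 to compound 3 (0.88 log units; beyond the scatter) and so lifts compound 3 clear of the scatter, which the two earlier compounds did not do between themselves. This position, on an aromatic carbon meta to a large group, therefore responds to a single fluoro in place of hydrogen. Nothing measured here accounts for the size of this step.

The compounds shown leave open whether chloro, methoxy or an amine at this place would give a similar step. They also leave open whether fluoro elsewhere on this ring would.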